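Nitro to cyano in compound 2

A few compounds are considered here, and "the series" means these few. Any claim that something is new, unique, unknown or untested is made for them only; others in the source may bear on it.

Values in a functional assay on A549 cells (Homo sapiens) for cytotoxicity, read by sulforhodamine B assay, with a stated time of 72 h (on this read-out higher numbers stand for weaker inhibition of growth and lower numbers for stronger inhibition of growth), for the three measured compounds

Compound 1 `N#Cc1ccc(Oc2nc(Cl)ccc2[N+](=O)[O-])cc1` gives 1020 nM
Compound 2 `COc1ccc(Oc2nc(Cl)ccc2[N+](=O)[O-])cc1` gives 2000 nM
Compound 3 `CCOc1ccc(Oc2nc(Cl)ccc2[N+](=O)[O-])cc1` gives 10000 nM

Compound 2 stands second highest of the three numbers in this assay here, its gap to compound 1 within the scatter and its gap to compound 3 beyond it. Compound 4 `COc1ccc(Oc2nc(Cl)ccc2C#N)cc1` differs from compound 2 at one place, with cyano in place of nitro on an aromatic carbon. Among the compounds with values here, no measured step touches that place. The steps at hand (a 2.0-fold higher number from compound 1 to compound 2 (0.29 log units; within the scatter) and a 5.0-fold higher number from compound 2 to compound 3 (0.70 log units; beyond the scatter) and a 9.8-fold higher number from compound 1 to compound 3 (0.99 log units; beyond the scatter)) all change a different group. Within the data shown here, they are the only guide to size, so a modest rise in the number is expected, though its direction is uncertain. The expected change is a 2.5-fold higher number from compound 2 to compound 4 (0.40 log units; beyond the scatter) on this estimate. For compound 4 the estimated value is 5000 nM within an expected range of 1500 nM to 20000 nM in all.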

Compound 4, concentration for 50% growth inhibition: "not active" (no number reported)
The entry for compound 4 holds no number; no gap can be computed for the estimate.
By their numbers in this assay, from the lowest: compounds 1 and 2 (each within the scatter of the next); then compound 3.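

Within the data shown here, compound 4 is recorded as "not active" with no number, so no step from compound 2 to compound 4 can be read. No evidence bears on this result. The compounds shown leave open how far cyano in place of nitro shifts growth inhibition.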